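The compounds below may be only part of what the source reports. "The series", "measured", "known", "first", "only" and "open" are said of these compounds alone.

Compound 1 `COC(=O)[C@@]1(C)CCC=C2[C@@H]1CC[C@@H](C)[C@]2(C)Cc1c[nH]c2ccc(Br)cc12` and compound 2 `COC(=O)[C@@]1(C)CCC=C2[C@@H]1CC[C@@H](C)[C@]2(C)Cc1c[nH]c2ccc(Cl)cc12` share a core and differ only in the halogen on the aromatic ring. In a functional assay on HBL-100 cells (Homo sapiens) for inhibition, read by sulforhodamine B assay, with a stated time of 48 h (on this read-out higher numbers stand for weaker inhibition of growth and lower numbers for stronger inhibition of growth), compound 1 gives 16000 nM, and compound 2 gives 17000 nM. The step of a 1.1-fold higher number from compound 1 to compound 2 (0.03 log units; within the scatter) is small. Within this pair compound 2 carries the higher number, yet the gap to compound 1 sits within the scatter, so no order can be read from it. Compound 3 `COC(=O)[C@@]1(C)CCC=C2[C@@H]1CC[C@@H](C)[C@]2(C)Cc1c[nH]c2ccc(OC)cc12` is the next member: methoxy in place of chloro on an aromatic carbon. Going by the values given here, no measured step swaps a halogen for a methoxy group here; the only step at hand, a 1.1-fold higher number from compound 1 to compound 2 (0.03 log units; within the scatter), exchanged one halogen for another and stayed within the scatter, which gives little guidance. The step of a 1.1-fold higher number from compound 2 to compound 3 (0.02 log units; within the scatter) is therefore expected to remain modest, with no clear direction. On that basis compound 3 is expected to give about 18000 nM, with a plausible range from 7000 nM to 45000 nM in this assay.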

Compound 3, concentration for 50% growth inhibition: 2100 nM
Beside the measured number, compound 3's estimate is 8.6-fold (0.93 log units) above it; measured number outside the range, below it.
By their numbers in this assay, from the lowest: compound 3; then compounds 1 and 2 (each within the scatter of the next).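

In this assay methoxy in place of chloro gives an 8.1-fold lower number from compound 2 to compound 3 (0.91 log units; beyond the scatter) and methoxy in place of bromo gives a 7.6-fold lower number from compound 1 to compound 3 (0.88 log units; beyond the scatter) and both steps lie beyond the scatter. The exchange of one halogen for the other showed no response at this aromatic carbon, whereas methoxy, which enters with one hydrogen-bond acceptor, now shows that the position can respond, with stronger inhibition of growth than either halogen gives. Nothing measured here accounts for this difference.

The compounds shown leave open whether the oxygen, the attached methyl group or the two together matter, and a hydroxy group or an ethoxy group on the same carbon would help to separate these possibilities. They also leave open how an amine at this position would compare with methoxy.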